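Cytotoxicity notes on a catechol-ether urea series

The compounds below may be only part of what the source reports. "The series", "measured", "known", "first", "only" and "open" are said of these compounds alone.

The series shares a urea bearing a 3,5-bis(trifluoromethyl)phenyl group, joined through an ethylene linker to a sulfonamide on a thiophene that carries an aryl ether. Compound 1 `O=C(NCCNS(=O)(=O)c1cc(-c2ccccc2Oc2ccc(O)c(O)c2)cs1)Nc1cc(C(F)(F)F)cc(C(F)(F)F)c1`, compound 2 `CC(C)c1ccc(Oc2ccc(O)c(O)c2)c(-c2ccsc2S(=O)(=O)NCCNC(=O)Nc2cc(C(F)(F)F)cc(C(F)(F)F)c2)c1` and compound 3 `O=C(NCCNS(=O)(=O)c1ccc(-c2ccccc2O[C@H]2CC[C@@H](O)CC2)s1)Nc1cc(C(F)(F)F)cc(C(F)(F)F)c1` have been run in an ADME assay on HEK-293T cells (Homo sapiens) for cytotoxicity, read by CCK-8 assay, with a stated time of 48 h; a higher number here means a weaker inhibitor, a lower number a stronger inhibitor. Compound 1 gives only a limit, > 50000 nM, and no number. Compound 2 likewise gives only a limit, > 20000 nM. Compound 3 gives a measured value of 14100 nM in this assay. Compound 2 therefore stands at the limit of > 20000 nM in this assay, at which 1 of the 3 values shown sits, with compound 1 at the limit of > 50000 nM in this assay, at which 1 of the 3 values shown sits; neither is a number that could be ordered against compound 3.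

Compound 4 `O=C(NCCNS(=O)(=O)c1sccc1-c1ccccc1Oc1ccc(O)c(O)c1)Nc1cc(C(F)(F)F)cc(C(F)(F)F)c1` is the next member. Its change from compound 2 is hydrogen in place of isopropyl on an aromatic carbon. Going by the values given here, no step between two measured compounds involves this group, so no measured size guides the expectation. Compound 4 is expected to remain weak in this assay, with an estimated value of 30000 nM (range 12000 nM to 80000 nM), meaning an expected step that the limit leaves unreadable from compound 2 to compound 4, most likely again reported only as a limit.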

Compound 4, half-maximal inhibitory concentration: 8900 nM
Compound 4: the middle estimate sits 3.4-fold (0.53 log units) above what was measured; the whole stated range lies above it.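

Hydrogen in place of isopropyl on this aromatic carbon, para to a 3,4-dihydroxyphenoxy group, gives an at least 2.2-fold lower number from compound 2 to compound 4 (0.35 log units; beyond the scatter) in this assay. Going by these compounds alone, this is the first single-place step readable, and it shows that the group at this position is not silent in this assay, with the isopropyl compound carrying the higher number of the pair. The step is a minimum size only, and nothing shown gives its cause, since compound 2 is reported as a limit: the limit of > 20000 nM in this assay, at which 1 of the 4 values shown sits.

Only hydrogen and isopropyl are shown on this carbon, so a methyl group or an amine there would be needed to tell whether the number follows the particular group. As far as these compounds go, it also remains open whether the step would hold with the ether of compound 3 in place of the 3,4-dihydroxyphenoxy group.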